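A few compounds are considered here, and "the series" means these few. Any claim that something is new, unique, unknown or untested is made for them only; others in the source may bear on it.

Three compounds share a core and differ only in the group on the amine nitrogen of the six-membered ring. Compound 1 `CN(C[C@H]1Cc2c(cccc2N2CCN(C3CC3)CC2)CN1)[C@H]1CCCc2cccnc21` carries cyclopropyl there and, in an ADME assay on microsomes from liver (Mus musculus) for metabolic stability, read by LC-MS, with a stated time of 10 min (a higher number here means that more of the compound is left, a lower number that less of the compound is left), compound 1 gives 7%. Compound 2 `CN(C[C@H]1Cc2c(cccc2N2CCN(C3COC3)CC2)CN1)[C@H]1CCCc2cccnc21` carries oxetan-3-yl, and in this assay compound 2 gives 50.8%. Compound 3 `CN(C[C@H]1Cc2c(cccc2N2CCNCC2)CN1)[C@H]1CCCc2cccnc21` carries hydrogen at that nitrogen, and in this assay compound 3 gives 19.9%. Compound 3 thus stands second of the three: the step of a number 12.9 percentage points higher from compound 1 to compound 3 (beyond the scatter) is modest, whereas the step of a number 30.9 percentage points lower from compound 2 to compound 3 (beyond the scatter) is large.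

Compound 4 `CCN1CCN(c2cccc3c2C[C@H](CN(C)[C@H]2CCCc4cccnc42)NC3)CC1` is not yet measured. Its difference from compound 3 is ethyl in place of hydrogen on an amine nitrogen in a ring.

Within the data shown here, two measured steps bear on this position. Replacing hydrogen with cyclopropyl lowered the number modestly, while replacing it with oxetan-3-yl raised it by a large amount. Ethyl resembles neither of these in a way the data can settle, so a step no larger than the modest one seen with cyclopropyl is expected, in either direction or none beyond the scatter.

Compound 4 is therefore estimated at 16%, within a range from 5% to 35%. The expected step is a number 3.9 percentage points lower from compound 3 to compound 4 (within the scatter).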

Compound 4, percent of the compound remaining: 18.8%
Compound 4: middle estimate off by 2.8 percentage points, on the low side; the measured number falls inside the stated range.
By their numbers in this assay, from the lowest: compound 1; then compounds 4 and 3 (each within the scatter of the next); then compound 2.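

In this assay, ethyl on the amine nitrogen in the ring gives a number 1.1 percentage points lower from compound 3 to compound 4 (within the scatter), so at this position this group cannot be told apart from plain hydrogen. The three groups on this nitrogen therefore do not act alike: the change from cyclopropyl gives a number 11.8 percentage points higher from compound 1 to compound 4 (beyond the scatter), and the change from oxetan-3-yl gives a number 32 percentage points lower from compound 2 to compound 4 (beyond the scatter), which shows that carrying a group here does not by itself set a compound apart from compound 3, and that the outcome depends on which group it is. Nothing at hand tells why these groups differ.

From the compounds shown here alone, it remains open whether a longer chain such as propyl, or a branched one such as isopropyl, would stay level with ethyl and hydrogen, or would move toward the number of compound 1. Going by these compounds, it is equally open whether the high number of compound 2 is particular to oxetan-3-yl or extends to a larger oxygen-containing ring such as tetrahydropyran-4-yl, or to an acetyl group on the same nitrogen.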